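The source may report more compounds than this note shows. Statements on the series, on what has been measured and on what is new or still open speak of the compounds shown alone.

Compound 1 `O=C1NC(=O)/C(=C\c2ccc(OCC(=O)N3N=C(c4ccc(F)cc4)CC3c3ccco3)cc2)S1`: 880 nM
Compound 2 `O=C1NC(=O)/C(=C\c2ccc(OCC(=O)N3N=C(c4ccc(F)cc4)CC3c3ccc(C(F)(F)F)cc3)cc2)S1`: 1300 nM
Compound 3 `O=C1NC(=O)/C(=C\c2ccc(OCC(=O)N3N=C(c4ccc(F)cc4)CC3c3ccc(Cl)c(Cl)c3)cc2)S1`: 800 nM

In an assay on cells for inhibition of histone deacetylase 4 (Homo sapiens), read by fluorescence, with a stated time of 30 min (a lower number here means a stronger inhibitor, a higher number a weaker inhibitor), compound 1 gives 880 nM. Compound 2 gives 1300 nM and compound 3 gives 800 nM. On these numbers compound 1 lies between the other two, but the three values sit within the scatter of one another: the steps of a 1.5-fold higher number from compound 1 to compound 2 (0.17 log units; within the scatter), a 1.1-fold lower number from compound 1 to compound 3 (0.04 log units; within the scatter) and a 1.6-fold lower number from compound 2 to compound 3 (0.21 log units; within the scatter) are all small.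

Compound 4 `O=C1NC(=O)/C(=C\c2ccc(OCC(=O)N3N=C(c4ccc(F)cc4F)CC3c3ccco3)cc2)S1` differs from compound 1 by fluoro in place of hydrogen on an aromatic carbon. Going by the values given here, none of the measured steps bears directly on this change. All three of them swap the group sitting on the saturated ring carbon, on a different part of the shared core, and the six-membered aromatic ring that carries the fluoro group stays the same in compounds 1, 2 and 3. What those steps do show is that changes elsewhere on this core have so far left this assay within its scatter, and nothing here points to a larger effect from a single added fluoro. The expectation for compound 4 is therefore a step of about no change at the digits printed from compound 1 to compound 4 (within the scatter), that is, no step beyond the scatter in either direction. Compound 4 is estimated at 880 nM, expected to fall between 400 nM and 1900 nM.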

Compound 4, half-maximal inhibitory concentration: 15000 nM
Beside the measured number, compound 4's estimate is 17-fold (1.23 log units) below it; the whole stated range lies below it.
By their numbers in this assay, from the lowest: compounds 3, 1 and 2 (each within the scatter of the next); then compound 4.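

In this assay, going from 4-fluorophenyl to 2,4-difluorophenyl gives a 17-fold higher number from compound 1 to compound 4 (1.23 log units; beyond the scatter) and thus a much weaker inhibitor. This shows that the assay can respond strongly to a change on the shared core, which compounds 1, 2 and 3 did not show: their swaps on the saturated ring carbon all stayed within the scatter. Here, the entering group is a single fluoro, just one heavy atom, placed on an aromatic carbon ortho to a large group and meta to a fluoro group, yet nothing among the data shown explains the size of this step.

The compounds shown leave open whether the same fluoro would have a comparable effect with 3,4-dichlorophenyl or 4-(trifluoromethyl)phenyl in place of furan-2-yl on the saturated ring carbon. They also leave open whether the loss is particular to fluoro, since a chloro, methyl or methoxy group on this same aromatic carbon could give a step of a quite different size.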